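A few compounds are considered here, and "the series" means these few. Any claim that something is new, unique, unknown or untested is made for them only; others in the source may bear on it.

Among the measured compounds shown here, compound 2 `COc1ccc(C(O)(c2cc3cc([N+](=O)[O-])cc(-c4ccccc4)c3o2)c2cncn2C)cc1` stands highest of the two numbers measured so far: in a functional assay on QG-56 cells (Homo sapiens) for antiproliferative activity (on this read-out higher numbers stand for weaker inhibition and lower numbers for stronger inhibition), compound 2 gives 4970 nM, whereas compound 1 `Cn1cncc1C(O)(c1ccc(C#N)cc1)c1cc2cc([N+](=O)[O-])cc(-c3ccccc3)c2o1` gives 1480 nM. Compound 3 `Cn1cncc1C(O)(c1ccc([N+](=O)[O-])cc1)c1cc2cc([N+](=O)[O-])cc(-c3ccccc3)c2o1` differs from compound 2 in one place: nitro in place of methoxy on an aromatic carbon. For the measured compounds named here, only one measured step bears on this change, and it does so indirectly, as it concerns the same position: a 3.4-fold higher number from compound 1 to compound 2 (0.53 log units; beyond the scatter), so the arrival of methoxy went with a higher number. Going by the values given here, no measured step introduces nitro. Compound 3 is therefore expected to give a lower number, a 2.8-fold lower number from compound 2 to compound 3 (0.44 log units; beyond the scatter), with an estimate of 1800 nM and a range from 700 nM to 4500 nM.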

Compound 3, half-maximal inhibitory concentration: 547 nM
For compound 3 the middle estimate is 3.3-fold (0.52 log units) above the measured one, outside the stated range (below it).
By their numbers in this assay, from the lowest: compound 3; then compound 1; then compound 2.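

On the aromatic carbon para to a large group, nitro now gives the lowest number of the three groups in this assay, with a 9.1-fold lower number from compound 2 to compound 3 (0.96 log units; beyond the scatter) and a 2.7-fold lower number from compound 1 to compound 3 (0.43 log units; beyond the scatter). Nitro therefore surpasses cyano as well as methoxy, so the order at this position runs nitro, cyano, methoxy, from lowest to highest number. Going by these compounds, whether an amine or a carboxylic acid on this carbon would fit into that order stays open, as does whether nitro keeps its lead when the shared core changes. No available evidence accounts for the order.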